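Methyl to Methoxy at the Limit of Growth Inhibition

The compounds below may be only part of what the source reports. "The series", "measured", "known", "first", "only" and "open" are said of these compounds alone.

In a functional assay on NCI-H460 cells (Homo sapiens) for inhibition, read by sulforhodamine B assay, with a stated time of 48 h (a higher number here means a weaker inhibitor of growth, a lower number a stronger inhibitor of growth), compound 1 `CC(C)(C)NCc1c(C(=O)O)nn(-c2ccccc2)c1-c1ccc(Br)cc1` gives > 585000 nM, which is a limit and not a number. Compound 2 `Cc1ccc(-c2c(CNC(C)(C)C)c(C(=O)O)nn2-c2ccccc2)cc1` gives > 688000 nM, again only a limit, so no measured number yet stands for it in this assay. Compound 3 `COc1ccc(-c2c(CNC(C)(C)C)c(C(=O)O)nn2-c2ccccc2)cc1` differs from compound 2 at one place, with methoxy in place of methyl on an aromatic carbon, para to a large group (methoxy in place of methyl on an aromatic carbon). Going by the values given here, one measured step bears on this change, namely a step that the two limits leave unreadable from compound 1 to compound 2, a replacement at the same place whose size cannot be read. It offers no measured size to carry over, so no step beyond the scatter is expected in this assay, and neither direction is favoured. The expected step is an at least 1.0-fold lower number from compound 2 to compound 3 (0.01 log units; that floor lies within the scatter). The estimate for compound 3 is 660000 nM, with an expected range from 300000 nM to 1000000 nM.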

Compound 3, concentration for 50% growth inhibition: > 659000 nM
Compound 3: only a limit was reported (the forecaster's own chance of this, stated with the estimate: 90%); the middle value does not contradict the limit.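

In this assay, compound 1, compound 2 and compound 3 all give only limits, so the steps from compound 2 to compound 3 and from compound 1 to compound 3 cannot be read. The compounds shown leave open whether bromo, methyl and methoxy at this place differ at all in growth inhibition.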